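The compounds below may be only part of what the source reports. "The series", "measured", "known", "first", "only" and "open" are said of these compounds alone.

Measured so far in an ADME assay on S2 cells (Drosophila melanogaster) for cytotoxicity, read by MTT assay; on this read-out lower numbers stand for an effect already at smaller amounts and higher numbers for an effect only at larger amounts of compound:
- Compound 1 `COC(=O)/C=C/[C@H]1C[C@@H](O)[C@@H](O)C1`: for compound 1 the read-out is a limit of the assay, > 350000 nM.
- Compound 2 `CCCCCCOC(=O)/C=C/[C@H]1C[C@@H](O)[C@@H](O)C1`: for compound 2 the read-out is also a limit, > 350000 nM.
- Compound 3 `O=C(/C=C/[C@H]1C[C@@H](O)[C@@H](O)C1)Nc1ccccc1`: for compound 3 the read-out is likewise a limit, > 200000 nM.

Compound 3 thus stands at a limit, as do the two other values; the limit of > 200000 nM in this assay, at which 1 of the 3 values shown sits, and the limit of > 350000 nM in this assay, at which 2 of the 3 values shown sit, mark where they sit. Within the data shown here, the only measured step, a step that the two limits leave unreadable from compound 1 to compound 2, is left unreadable by its two limits, so no size of effect has yet been seen. Compound 4 `CCNC(=O)/C=C/[C@H]1C[C@@H](O)[C@@H](O)C1` carries the change (ethyl in place of phenyl on an amide-type nitrogen). Among the measured compounds shown here, no measured step bears on this change, and nothing here shows any compound reaching an effect. The expectation for compound 4 is therefore a read-out again at or beyond the limit, no change beyond the scatter: an estimated 400000 nM with a range from 200000 nM to 1000000 nM, meaning an expected step that the limit leaves unreadable from compound 3 to compound 4.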

Compound 4, half-maximal effective concentration: > 250000 nM
Compound 4 gave a limit, no number (the forecaster's own chance of this, stated with the estimate: 85%); the middle value is on the limit's open side.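

The steps from compound 3 to compound 4 and from compound 1 to compound 4 cannot be read: all three compounds give only limits, not numbers. Still open is what amount of any compound shown would produce an effect on these cells, and whether changing the group alters it.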